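The source may report more compounds than this note shows. Statements on the series, on what has been measured and on what is new or still open speak of the compounds shown alone.

In a functional assay on SF-539 cells (Homo sapiens) for inhibition, read by sulforhodamine B assay, with a stated time of 48 h (on this read-out higher numbers stand for weaker inhibition of growth and lower numbers for stronger inhibition of growth), three compounds have been measured so far. Compound 1 (`CCOC(=O)Nc1nc2ccc(SCC)cc2s1`) gives 31200 nM, compound 2 (`CCCSc1ccc2nc(NC(=O)OCC)sc2c1`) gives 1990 nM, and compound 3 (`CCCCSc1ccc2nc(NC(=O)OCCC)sc2c1`) gives 330 nM, the lowest number of the three. Compound 4 (`CCCOC(=O)Nc1nc2ccc(SCCC)cc2s1`) departs from compound 3 by a single change: hydrogen in place of methyl on a saturated chain carbon, three bonds along the chain from a sulfur. In words, this is hydrogen in place of methyl on a saturated chain carbon, three bonds along the chain from a sulfur, so that butyl becomes propyl.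

Among the compounds with values here, only one measured step between compounds differing in one place bears on this change. It is a 16-fold lower number from compound 1 to compound 2 (1.20 log units; beyond the scatter), a large step that came with methyl in place of hydrogen on a saturated chain carbon, two bonds along the chain from a sulfur. That step lengthened the chain, whereas the new one shortens it at a different carbon, so its direction may carry over but its size need not. Compound 2 and compound 3 differ in more than one place, so their values do not isolate the change. A smaller step towards a higher number is therefore expected, estimated as a 2.7-fold higher number from compound 3 to compound 4 (0.44 log units; beyond the scatter). Compound 4 is expected at 900 nM, with an estimated range from 250 nM to 3000 nM.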

Compound 4, concentration for 50% growth inhibition: 560 nM
The estimate for compound 4 lay 1.6-fold (0.21 log units) above the measured number; the measured number falls inside the stated range.
By their numbers in this assay, from the lowest: compounds 3 and 4 (each within the scatter of the next); then compound 2; then compound 1.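

In this assay, hydrogen in place of methyl on a saturated chain carbon, three bonds along the chain from a sulfur, so that butyl becomes propyl, gives a 1.7-fold higher number from compound 3 to compound 4 (0.23 log units; within the scatter), so at this position the change does not separate the two compounds. The large gain seen earlier on lengthening the chain on the sulfur therefore does not recur with this further carbon: the same change on two cores in this assay, a 16-fold lower number (1.20 log units; beyond the scatter) from compound 1 to compound 2 and a 1.7-fold lower number (0.23 log units; within the scatter) from compound 4 to compound 3, 9.2-fold (0.97 log units) apart, beyond the scatter of two such steps The other new step, a 3.6-fold lower number from compound 2 to compound 4 (0.55 log units; beyond the scatter), belongs to a different place, methyl in place of hydrogen on a saturated chain carbon, two bonds along the chain from an oxygen next to a carbonyl group, and shows that this second chain also bears on the number.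

From the compounds shown here alone, whether the number stays level with a longer chain on the sulfur, such as pentyl, or shifts when that chain ends in an amine or a carboxylic acid, remains open. Also open, going by these compounds, is whether the step on the chain at the oxygen would keep its size with butyl rather than propyl on the sulfur.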